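Adding a Bromine to a Methoxyphenyl Group in Two Series

A few compounds are considered here, and "the series" means these few. Any claim that something is new, unique, unknown or untested is made for them only; others in the source may bear on it.

Measured so far:
Compound 1, `COc1ccc(-c2cn(-c3cc(OC)c(OC)c(OC)c3)nn2)cc1`, in a functional assay on K562 cells (Homo sapiens) for cytotoxicity, read by MTT assay, with a stated time of 5 days (on this read-out lower numbers stand for stronger inhibition and higher numbers for weaker inhibition), gives > 10000 nM, which is a limit of the assay, not a number.
Compound 2, `COc1ccc(-c2cn(-c3cc(OC)c(OC)c(OC)c3)nn2)cc1Br`, in this assay gives > 10000 nM, again a limit.
Compound 3, `COc1ccc(Cn2cc(-c3cc(OC)c(OC)c(OC)c3)nn2)cc1`, in this assay gives > 10000 nM, also a limit.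

Compound 1 and compound 2 differ in one place only: bromo in place of hydrogen on an aromatic carbon. Because both results are limits, the measured step is a step that the two limits leave unreadable from compound 1 to compound 2. Nothing can be said about whether adding the bromine helped or hurt in that pair.

Compound 3 is built on a different core from compound 1; the difference between the two cores is not broken down here. Its own result sits at the same limit, so on its own it tells nothing about order among the three.

Compound 4, `COc1ccc(Cn2cc(-c3cc(OC)c(OC)c(OC)c3)nn2)cc1Br`, is the one still to be measured in this assay. It differs from compound 3 by the same change that turns compound 1 into compound 2: bromo in place of hydrogen on an aromatic carbon. The surroundings of the new bromine are described in the same words in both pairs.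

For compound 4 the expected step in this assay is a step that the limit leaves unreadable from compound 3 to compound 4. That expectation rests on the limit of > 10000 nM in this assay, at which 3 of the 3 values shown sit, and on the step that the two limits leave unreadable from compound 1 to compound 2, which gives no readable size to carry across. Compound 4 is therefore estimated at 20000 nM, with a likely range from 8000 nM to 60000 nM, and most probably the assay will again report only a limit.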

Compound 4, half-maximal inhibitory concentration: > 10000 nM
Compound 4 ended at the assay's limit; the forecaster's own chance of this, stated with the estimate: 80%; the middle value is on the limit's open side.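

In this assay compound 4 gives > 10000 nM, which is a limit of the assay and not a number. Compound 3 also stands at a limit, so no step can be read between compound 3 and compound 4, because every result shown is the same limit: the limit of > 10000 nM in this assay, at which 4 of the 4 values shown sit.

The compounds shown leave open whether bromo in place of hydrogen helps or hurts in either pair, and how the two cores compare.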